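A few compounds are considered here, and "the series" means these few. Any claim that something is new, unique, unknown or untested is made for them only; others in the source may bear on it.

Compound 1 `COc1ccccc1/C=c1/[nH]c(=O)/c(=C\c2cccc(Cl)c2Cl)[nH]c1=O` — "not determined" (no result reported)
Compound 2 `C=CCn1c(=O)/c(=C\c2cccc(F)c2)[nH]c(=O)/c1=C\c1ccccc1OC` — 6500 nM
Compound 3 `C=CCn1c(=O)/c(=C\c2ccc(Cl)c(Cl)c2)[nH]c(=O)/c1=C\c1ccccc1OC` — "not active" (no number reported)

In a functional assay on MOLT-4 cells (Homo sapiens) for cytotoxicity, read by CCK-8 assay, with a stated time of 72 h (on this read-out higher numbers stand for weaker inhibition and lower numbers for stronger inhibition), compound 2 gives 6500 nM. Compound 3 has no such figure: for it this assay records "not active" (no number reported), an entry without a number behind it. Compound 1 is in a similar position, as for it this assay records "not determined" (no result reported). Among the compounds with values here, compound 3 therefore stands without a single number, one of two such entries in this set, and no step between two measured compounds can be sized from these data. Within the data shown here, the only comparison available is that compound 2, which carries a 3-fluorophenyl group, shows a measurable value, while compound 3 does not.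

Compound 4 `C=CCn1c(=O)/c(=C\c2ccc(F)c(Br)c2)[nH]c(=O)/c1=C\c1ccccc1OC` differs from compound 3 in one place: 3-bromo-4-fluorophenyl in place of 3,4-dichlorophenyl on a double-bonded chain carbon bound to an aromatic carbon. Among the measured compounds shown here, because no step between measured compounds is given, nothing here shows how large a change in this assay such an exchange brings or in which direction it would go; the one point of reference is that compound 3 gave no number. On that basis compound 4 is expected to remain weak, with an estimated value of 20000 nM and a range from 5000 nM to 80000 nM, and with a substantial chance that this assay again reports no number for it.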

Compound 4, half-maximal inhibitory concentration: "not active" (no number reported)
Nothing numeric was reported for compound 4; no gap can be computed for the estimate.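

In this assay, within the data shown here, compound 3 gives "not active" (no number reported) and compound 4 gives "not active" (no number reported) as well, so no step between them can be read. The compounds shown leave open how far, and in which direction, exchanging 3,4-dichlorophenyl for 3-bromo-4-fluorophenyl shifts this read-out. No evidence presented here bears on this result.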